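A Trifluoromethyl Added to the Benzyl Ether of Compound 3

The compounds below may be only part of what the source reports. "The series", "measured", "known", "first", "only" and "open" are said of these compounds alone.

Compound 1 `COc1cccc(/C=C/c2cc3c(c(=O)n(C)c(=O)n3C)n2C)c1`: 1240 nM in an assay on isolated protein for inhibition of Amine oxidase [flavin-containing] A (Homo sapiens), read by luminescence, with a stated time of 1 h; on this read-out lower numbers stand for stronger inhibition and higher numbers for weaker inhibition.
Compound 2 `Cn1c(=O)c2c(cc(/C=C/c3ccc(C#N)cc3)n2C)n(C)c1=O`: > 10000 nM; this is a limit of the assay, not a number.
Compound 3 `Cn1c(=O)c2c(cc(OCc3ccc(Cl)cc3)n2C)n(C)c1=O`: 2870 nM.

Among the two numbers shown, compound 3 stands highest; the nearest is compound 1, which gives a lower number, beyond the scatter. Compound 4 `Cn1c(=O)c2c(cc(OCc3ccc(Cl)c(C(F)(F)F)c3)n2C)n(C)c1=O` differs from compound 3 by trifluoromethyl in place of hydrogen on an aromatic carbon. Among the measured compounds shown here, the only measured step, an at least 8.0-fold higher number from compound 1 to compound 2 (0.90 log units; beyond the scatter), concerns a different ring and a different change, so no measured step bears on this one. Compound 4 is therefore expected to sit near compound 3, with a step of a 1.3-fold lower number from compound 3 to compound 4 (0.12 log units; within the scatter) that may fall either way. Compound 4 is estimated at 2200 nM, ranging from 500 nM to 10000 nM.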

Compound 4, half-maximal inhibitory concentration: > 10000 nM
Compound 4: only a limit was reported; the forecaster's own chance of this, stated with the estimate: 20%; middle value at least 4.5-fold (0.65 log units) from the limit.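

Trifluoromethyl in place of hydrogen on this aromatic carbon, ortho to a chloro group, weakens inhibition on the benzyl ether, with an at least 3.4-fold higher number from compound 3 to compound 4 (0.54 log units; beyond the scatter). Earlier, the only measured loss came from compound 1 to compound 2, through a change on a different ring and chain. In this assay compound 4 gives > 10000 nM, a limit of the assay and not a number, so the step is only a minimum: the limit of > 10000 nM in this assay, at which 2 of the 4 values shown sit.

The compounds shown leave open whether a fluoro, a methyl or an amine on this carbon would keep the inhibition of compound 3. They also leave open whether trifluoromethyl would weaken inhibition without the chloro group.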